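The compounds below may be only part of what the source reports. "The series", "measured", "known", "first", "only" and "open" are said of these compounds alone.

Among the compounds with values here, compound 3 `COc1ccc(/C=C2\CCC/C(=C\c3ccc(Br)cc3)C2=O)cc1OC` is the only member of the series with a numbered result: in a functional assay on A549 cells (Homo sapiens) for cytotoxicity, read by MTT assay, with a stated time of 72 h (a lower number here means a stronger inhibitor, a higher number a weaker inhibitor), compound 3 gives 16000 nM. Compound 1 `COc1cccc(/C=C2\CCC/C(=C\c3ccc(Cl)cc3Cl)C2=O)c1OC` returns only a limit, > 20000 nM, in this assay. Compound 2 `COc1ccc(/C=C2\CCC/C(=C\c3cccc(OC)c3OC)C2=O)c(OC)c1` likewise returns a limit, > 20000 nM, in this assay. Within the data shown here, two of the three results therefore sit at the limit of > 20000 nM in this assay, at which 2 of the 3 values shown sit, and compound 3 is the sole anchor for any reading of the series. Compound 4 `COc1ccc(/C=C2\CCC/C(=C\c3ccc(O)c(Cl)c3)C2=O)cc1OC` is not yet measured in this assay; it differs from compound 3 by 3-chloro-4-hydroxyphenyl in place of 4-bromophenyl on a double-bonded chain carbon bound to a double-bonded ring carbon. Among the measured compounds shown here, no measured pair isolates this change, so its direction is open; a small step of a 1.6-fold lower number from compound 3 to compound 4 (0.20 log units; within the scatter) is expected, at the edge of the usual scatter. Compound 4 is estimated at 10000 nM in this assay, with a range from 4000 nM to 30000 nM.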

Compound 4, half-maximal inhibitory concentration: > 20000 nM
Compound 4: only a limit was reported; the forecaster's own chance of this, stated with the estimate: 25%; at least 2.0-fold (0.30 log units) between middle value and limit.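

In this assay compound 4 gives > 20000 nM, which is a limit and not a number. Replacing 4-bromophenyl with 3-chloro-4-hydroxyphenyl gives an at least 1.2-fold higher number from compound 3 to compound 4 (0.09 log units; that floor lies within the scatter), so this change brings no lower number, while its floor does not establish a real loss. Compound 3 remains the sole numbered anchor: the limit of > 20000 nM in this assay, at which 3 of the 4 values shown sit.

As far as these compounds go, how far compound 4 lies past its limit stays open. Also open, from the compounds shown here alone, is whether an amine or a carboxylic acid in place of 4-bromophenyl would give a lower number than compound 3.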